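Oximes and triazole ethers against seizures in mice

This account rests on a few compounds, and the source may have more. Where it says the series, first, only, none or still open, it means among the compounds named here.

Measured compounds and their values:
compound 1, `Cc1ccc(-c2nc3ccc(Br)cn3c2/C=N/O)cc1` — 20 mg/kg
compound 2, `Cc1ccc(-c2nc3ccc(Br)cn3c2/C=N/OCc2cn(Cc3ccc([N+](=O)[O-])cc3)nn2)cc1` — 20 mg/kg
compound 3, `O/N=C/c1c(-c2ccc(F)cc2)nc2ccc(Br)cn12` — 40 mg/kg

All three were tested in a functional assay on the whole organism (strain NMRI) with Mus musculus as the target, with a stated time of 0.5 h; on this read-out lower numbers stand for an effect already at smaller amounts and higher numbers for an effect only at larger amounts of compound. Compound 1 gives 20 mg/kg, and compound 2, which carries a much larger group on the oxime oxygen, gives 20 mg/kg; the two numbers are level at the digits shown. The difference between the cores of compound 1 and compound 2 is not broken down here. Compound 3 gives 40 mg/kg. From compound 1 to compound 3 the change is fluoro in place of methyl on an aromatic carbon, and it produced a 2.0-fold higher number from compound 1 to compound 3 (0.30 log units; within the scatter).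

Compound 4, `O=[N+]([O-])c1ccc(Cn2cc(CO/N=C/c3c(-c4ccc(F)cc4)nc4ccc(Br)cn34)nn2)cc1`, has not yet been measured in this assay. It stands to compound 2 as compound 3 stands to compound 1: the change is fluoro in place of methyl on an aromatic carbon, the same change at the same place.

Compound 4 is therefore expected to give about 30 mg/kg in this assay. The expected step is a 1.5-fold higher number from compound 2 to compound 4 (0.18 log units; within the scatter), because the same change gave a 2.0-fold higher number from compound 1 to compound 3 (0.30 log units; within the scatter). Within the data shown here, the estimate is expected to lie between 15 mg/kg and 60 mg/kg; only two compounds show this change, so the expectation rests on that single pair.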

Compound 4, minimum effective dose: 40 mg/kg
The estimate for compound 4 lay 1.3-fold (0.12 log units) below the measured number; measured number inside the range.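

In this assay, putting 4-fluorophenyl in place of 4-methylphenyl gave a 2.0-fold higher number from compound 2 to compound 4 (0.30 log units; within the scatter). Set side by side, the two steps agree, so in these four compounds the swap reads the same whether the oxime is free or carries the large triazole ether: the same change on two cores in this assay, a 2.0-fold higher number (0.30 log units; within the scatter) from compound 1 to compound 3 and a 2.0-fold higher number (0.30 log units; within the scatter) from compound 2 to compound 4, 1.0-fold (0.00 log units) apart, within the scatter of two such steps This does not show that the swap itself has a real effect on the dose needed, since each step lies within the usual scatter, and two pairs cannot show that the agreement would hold on any other core.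

The compounds shown leave open how other groups in place of the methyl would read, such as chloro, methoxy or an amine, and whether a step large enough to stand clear of the scatter would also carry from one core to the other. They also leave open how the same swap would read on a core that has a chloro group or a plain hydrogen where these four compounds carry bromo.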